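This account rests on a few compounds, and the source may have more. Where it says the series, first, only, none or still open, it means among the compounds named here.

In a functional assay on the whole organism with Rattus norvegicus as the target (a higher number here means that more compound is needed for the effect, a lower number that less compound is needed), compound 1 (`CCNc1cccc(NC(=O)C(=O)OCC)c1C#N`) gives 0.03 mg/kg, and compound 2 (`CCOC(=O)C(=O)Nc1cccc(N(CC)CC)c1C#N`) gives 0.9 mg/kg, the higher of the two numbers. Compound 3 (`CCOC(=O)C(=O)Nc1cccc(C)c1C#N`) has methyl in place of diethylamino on an aromatic carbon. Within the data shown here, only one measured step bears on this, and only in part: ethyl in place of hydrogen on a nitrogen on an aromatic ring gave a 30-fold higher number from compound 1 to compound 2 (1.48 log units; beyond the scatter) as a large rise. Among the measured compounds shown here, no measured step covers removal of that nitrogen, so a moderate fall is expected, not a full return to the value of compound 1. The expected change is a 4.5-fold lower number from compound 2 to compound 3 (0.65 log units; beyond the scatter) in this direction. The estimate for compound 3 is 0.2 mg/kg (expected range 0.03 mg/kg to 1 mg/kg).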

Compound 3, dose for half-maximal effect: 4.6 mg/kg
The estimate for compound 3 lay 23-fold (1.36 log units) below the measured number; the measured number lies above the stated range.
By their numbers in this assay, from the lowest: compound 1; then compound 2; then compound 3.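

In this assay, methyl on this aromatic carbon, ortho to a cyano group, does not restore a low number: the change gives a 5.1-fold higher number from compound 2 to compound 3 (0.71 log units; beyond the scatter), and against ethylamino it gives a 150-fold higher number from compound 1 to compound 3 (2.19 log units; beyond the scatter). Among these three groups the order is therefore ethylamino lowest, then diethylamino, then methyl, so removing the nitrogen raises the number instead of lowering it. No evidence at hand explains this order. The compounds leave open how a primary amine or a dimethylamino group would fare here. They also leave open whether methoxy, with oxygen in place of that nitrogen, would keep the low number.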